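This account rests on a few compounds, and the source may have more. Where it says the series, first, only, none or still open, it means among the compounds named here.

Compound 1 `O=C(NCCCNc1ccnc(Nc2cccc(NC(=O)N3CCCC3)c2)n1)C1CCC1` gives, in an assay on HEK293 cells for displacement of a labelled ligand from serine/threonine-protein kinase TBK1 (Homo sapiens), read by NanoBRET (on this read-out higher numbers stand for weaker inhibition and lower numbers for stronger inhibition), a value that is only a limit of the assay, > 10000 nM. Compound 2 `O=C(NCCCNc1nc(Nc2cccc(NC(=O)N3CCCC3)c2)ncc1Br)C1CCC1` gives 338 nM in this assay. Compound 3 `NS(=O)(=O)c1ccc(CNc2nc(Nc3cccc(NC(=O)N4CCCC4)c3)ncc2C2CC2)cc1` gives in this assay again only a limit, > 10000 nM.

Compound 3 therefore stands at the limit of this assay, a limit at which, as the limit of > 10000 nM in this assay, at which 2 of the 3 values shown sit, shows, two of the three values sit, so its number cannot be placed. Compound 4 `O=C(NCCCNc1nc(Nc2cccc(NC(=O)N3CCCC3)c2)ncc1C1CC1)C1CCC1` is compound 3 with 2-((cyclobutylcarbonyl)amino)ethyl in place of 4-sulfamoylphenyl on a saturated chain carbon bound to a nitrogen on an aromatic ring. Among the compounds with values here, no measured step covers this exchange of the chain. The only step shown, an at least 29-fold lower number from compound 1 to compound 2 (1.47 log units; beyond the scatter), concerns the aromatic carbon and leaves the chain untouched, so it bears on the change only indirectly, in that compound 2 carries the same chain as compound 4 and reaches a measured number. On that basis compound 4 is expected to move to a lower number than the limit of compound 3, a step of an at least 6.6-fold lower number from compound 3 to compound 4 (0.82 log units; beyond the scatter), with the chance that it too only reaches the limit. The estimate for compound 4 is 1500 nM, between 300 nM and 10000 nM.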

Compound 4, half-maximal inhibitory concentration: 2580 nM
Estimate against measurement, compound 4: 1.7-fold (0.24 log units) below; low and high end bracket the measured number.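

Within the data shown here, with cyclopropyl on the aromatic carbon in both compounds, 2-((cyclobutylcarbonyl)amino)ethyl in place of 4-sulfamoylphenyl gives an at least 3.8-fold lower number from compound 3 to compound 4 (0.58 log units; beyond the scatter) in this assay, the first sign that the group at this place on the chain matters. The aromatic carbon now shows three groups in order: with the chain held constant, cyclopropyl gives an at least 3.8-fold lower number from compound 1 to compound 4 (0.58 log units; beyond the scatter), yet bromo remains ahead of it, with a 7.6-fold higher number from compound 2 to compound 4 (0.88 log units; beyond the scatter). Compound 1 and compound 3 each give only a limit, so the two steps that start from them are bounds, not sizes: the limit of > 10000 nM in this assay, at which 2 of the 4 values shown sit.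

As far as these compounds go, what remains open is how chloro, methyl or a nitrile on the aromatic carbon would rank against bromo and cyclopropyl. From the compounds shown here alone, it is also open whether a longer chain, an amine or a carboxylic acid in place of 2-((cyclobutylcarbonyl)amino)ethyl would keep the number of compound 4.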